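The compounds below may be only part of what the source reports. "The series", "measured", "known", "first", "only" and "open" are said of these compounds alone.

Measured so far:
compound 1 `COc1cc(-c2nc(SCc3cn(CC(=O)NC(=O)Nc4ccccn4)nn3)nc(Nc3ccc(C)cc3)c2C#N)cc(OC)c1OC` — 7030 nM
compound 2 `Cc1ccc(Nc2nc(SCc3cn(CC(=O)NC(=O)Nc4ccccn4)nn3)nc(-c3ccc(C)cc3)c2C#N)cc1` — 9890 nM

In a functional assay on MGC-803 cells (Homo sapiens) for inhibition, read by MTT assay, with a stated time of 72 h (on this read-out higher numbers stand for weaker inhibition and lower numbers for stronger inhibition), compound 1 gives 7030 nM and compound 2 gives 9890 nM. Compound 2 carries the higher of the two numbers, but the gap a 1.4-fold higher number from compound 1 to compound 2 (0.15 log units; within the scatter) lies within the scatter, so no order between compound 1 and compound 2 is drawn from it.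

Compound 3 `Cc1ccc(Nc2nc(SCc3cn(CC(=O)NC(=O)Nc4ccccn4)nn3)nc(-c3ccc(Br)cc3)c2C#N)cc1` is not yet measured. It differs from compound 2 by bromo in place of methyl on an aromatic carbon, a one-for-one swap at the same position. Going by the values given here, the only measured step, a 1.4-fold higher number from compound 1 to compound 2 (0.15 log units; within the scatter), exchanges the whole aryl group and does not bear on a methyl-to-bromo swap; nothing measured here speaks to that exchange directly. In the absence of a guiding step, the expectation in this assay is a shift no larger than the scatter, in no preferred direction. Compound 3 is therefore estimated at 8500 nM, with a range from 3800 nM to 19000 nM. This amounts to an expected step of a 1.2-fold lower number from compound 2 to compound 3 (0.07 log units; within the scatter).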

Compound 3, half-maximal inhibitory concentration: 13900 nM
The estimate for compound 3 lay 1.6-fold (0.21 log units) below the measured number, within the range that was stated.
By their numbers in this assay, from the lowest: compounds 1, 2 and 3 (each within the scatter of the next).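

In this assay, bromo in place of methyl on the aromatic carbon para to a large group gives a 1.4-fold higher number from compound 2 to compound 3 (0.15 log units; within the scatter), so this one-atom swap at that position does not separate the 4-methylphenyl and 4-bromophenyl compounds. The wider exchange of 3,4,5-trimethoxyphenyl for 4-bromophenyl gives a 2.0-fold higher number from compound 1 to compound 3 (0.30 log units; within the scatter), which leaves all three aryl groups at this position within the scatter of one another, with no order among them. Nothing available bears on the reason for these numbers.

On these data alone, whether an amine, a carboxylic acid or a longer chain at this place would move the number beyond the scatter stays open. The compounds shown also share everything outside this aryl group, so the response to changes elsewhere on the shared core is open too.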